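Replacing the 3-(dimethylamino)propyl group of compound 2

The compounds below may be only part of what the source reports. "The series", "measured", "known", "first", "only" and "open" are said of these compounds alone.

In a functional assay on RS4-11 cells (Homo sapiens) for inhibition, read by CCK-8 assay, with a stated time of 72 h (a higher number here means a weaker inhibitor, a lower number a stronger inhibitor), compound 1 (`CC1(C)CCC(CN2CCN(c3ccc(C(=O)NS(=O)(=O)c4ccc(NCC5CCOCC5)c([N+](=O)[O-])c4)c(Oc4cnc5[nH]ccc5c4)c3)CC2)=C(c2ccccc2C(F)(F)F)C1`) gives 18 nM and compound 2 (`CN(C)CCCNc1ccc(S(=O)(=O)NC(=O)c2ccc(N3CCN(CC4=C(c5ccc(C(F)(F)F)cc5)CC(C)(C)CC4)CC3)cc2Oc2cnc3[nH]ccc3c2)cc1[N+](=O)[O-]`) gives 3.9 nM as the lower of the two numbers, a gap beyond the scatter. Compound 3 (`CC1(C)CCC(CN2CCN(c3ccc(C(=O)NS(=O)(=O)c4ccc(NC5CCOC5)c([N+](=O)[O-])c4)c(Oc4cnc5[nH]ccc5c4)c3)CC2)=C(c2ccc(C(F)(F)F)cc2)C1`) is not yet measured and carries oxolan-3-yl in place of 3-(dimethylamino)propyl on a nitrogen on an aromatic ring. Among the compounds with values here, no measured pair shows this change alone. Compound 1 also lacks the 3-(dimethylamino)propyl group and reads 18 nM in this assay but differs from compound 2 elsewhere too, so it serves only as a loose guide. The expected step is a 3.1-fold higher number from compound 2 to compound 3 (0.49 log units; beyond the scatter) in this assay towards a weaker inhibitor, probably beyond the scatter but not far beyond it. For compound 3 the estimate is 12 nM with an expected range from 3 nM to 50 nM for now.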

Compound 3, half-maximal inhibitory concentration: 32 nM
For compound 3 the middle estimate is 2.7-fold (0.43 log units) below the measured one, within the range that was stated.
By their numbers in this assay, from the lowest: compound 2; then compounds 1 and 3 (each within the scatter of the next).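

In this assay, within the data shown here, the exchange of 3-(dimethylamino)propyl for oxolan-3-yl on a nitrogen on an aromatic ring gives an 8.2-fold higher number from compound 2 to compound 3 (0.91 log units; beyond the scatter) towards a weaker inhibitor, the first reading of this substituent with the rest of the molecule held constant. The substituent on this nitrogen therefore matters in this series, and for this one pair the open chain carrying the dimethylamino group gives the stronger inhibitor. Nothing measured here explains the step.

The compounds shown leave open whether the step follows the dimethylamino group or the chain itself. A 3-methoxypropyl chain would keep the chain without the dimethylamino group, while 1-methylpiperidin-4-yl would put an amine back on a ring, and either group would help separate the two readings.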